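A few compounds are considered here, and "the series" means these few. Any claim that something is new, unique, unknown or untested is made for them only; others in the source may bear on it.

Compound 1 `C#CCSc1nc(NCCC(C)C)c2ccncc2n1` is one of three compounds that share a core and differ only at a nitrogen on an aromatic ring. In a functional assay on PC-3 cells (Homo sapiens) for inhibition, read by MTT assay, with a stated time of 72 h (a higher number here means a weaker inhibitor, a lower number a stronger inhibitor), compound 1 gives > 80000 nM, which is a limit of the assay rather than a number. Compound 2 `C#CCSc1nc(NCCC#N)c2ccncc2n1` gives > 80000 nM in this assay, again a limit. Compound 3 `C#CCSc1nc(Nc2ccc([N+](=O)[O-])cc2)c2ccncc2n1` gives > 80000 nM in this assay, also a limit. Going by the values given here, because of the limit of > 80000 nM in this assay, at which 3 of the 3 values shown sit, the step that the two limits leave unreadable from compound 1 to compound 2 cannot be read, and no measured step shows how a change at that nitrogen moves the read-out. Compound 4 `C#CCSc1nc(Nc2ccc(O)cc2)c2ccncc2n1` has not yet been measured; it differs from compound 1 by 4-hydroxyphenyl in place of isopentyl on a nitrogen on an aromatic ring. Among the compounds with values here, no measured step bears directly on this change, and compound 3, which also carries an aromatic ring on that nitrogen, sits at the limit. Compound 4 is therefore expected to sit at or near the limit as well. The expected step from compound 1 to compound 4 in this assay is a step that the limit leaves unreadable from compound 1 to compound 4, which is nothing readable beyond the scatter. The estimate for compound 4 is 100000 nM, between 20000 nM and 300000 nM, most likely reported again as a limit.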

Compound 4, half-maximal inhibitory concentration: > 80000 nM
Compound 4 ended at the assay's limit (the forecaster's own chance of this, stated with the estimate: 75%); the middle value is on the limit's open side.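

Going by these compounds alone, no step linking compound 4 with compound 1, compound 2 or compound 3 can be read, since all four compounds stand at a limit: the limit of > 80000 nM in this assay, at which 4 of the 4 values shown sit. The compounds shown leave open whether any group on that nitrogen gives a value that can be read as a number.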